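The source may hold more compounds than are shown below. What is called first, only, known or untested is meant among the compounds shown, and "the series" means these compounds.

Measured so far in a functional assay (Homo sapiens) for antiproliferative activity; a higher number here means a weaker inhibitor of growth, a lower number a stronger inhibitor of growth:
compound 1 `Cc1sc2nc(-c3ccncc3)c(/C=N/NC(=N)N)n2c1C` gives 83200 nM
compound 2 `Cc1cn2c(/C=N/NC(=N)N)c(-c3cccnc3)nc2s1` gives 25700 nM
compound 3 `N=C(N)N/N=C/c1c(-c2ccccn2)nc2sc(Cl)cn12` gives 15100 nM

In this assay compound 3 stands level with compound 2, since the gap between these two lies within the scatter. Compound 1 has a clearly higher number, beyond the scatter, so compound 3 is the stronger inhibitor of growth in that pair.

The next compound, compound 4 `N=C(N)N/N=C/c1c(-c2cccnc2)nc2sc(Cl)cn12`, has not yet been measured. It differs from compound 3 by having pyridin-3-yl in place of pyridin-2-yl on an aromatic carbon and is otherwise the same. Within the data shown here, no pair of measured compounds isolates this change, so the data give no direct size for it. Compound 2 also carries pyridin-3-yl and gives 25700 nM in this assay, which lies within the scatter of compound 3. No step beyond the scatter is therefore expected. The estimated step is a 1.2-fold higher number from compound 3 to compound 4 (0.08 log units; within the scatter) and it is expected to stay within the scatter. For compound 4 the expected value is 18000 nM, with an estimated range from 7000 nM to 45000 nM.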

Compound 4, concentration for total growth inhibition: 36300 nM
Compound 4: middle estimate off by 2.0-fold (0.30 log units), on the low side; the measured number falls inside the stated range.
By their numbers in this assay, from the lowest: compounds 3, 2 and 4 (each within the scatter of the next, the first and the last beyond it); then compound 1.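

On the aromatic carbon of the five-membered ring, with the chloro group kept, pyridin-3-yl in place of pyridin-2-yl gives in this assay a 2.4-fold higher number from compound 3 to compound 4 (0.38 log units; beyond the scatter), a modest step beyond the scatter and the first direct size for this change, so the two pyridine attachments are not equivalent here. Chloro in place of methyl, with pyridin-3-yl kept, gives a 1.4-fold higher number from compound 2 to compound 4 (0.15 log units; within the scatter), which lies within the scatter, so this exchange shows no measurable change in this pair. No information is available that would explain either result.

Pyridin-4-yl appears only in compound 1, which differs from the others in more than one place, so its standing on the chloro-bearing core remains open. Also open, going by these compounds, is how a plain phenyl ring would compare with these pyridines at this position.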